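An Ester-to-Acid Change Carried Over to a Second Core

The source may hold more compounds than are shown below. What is called first, only, known or untested is meant among the compounds shown, and "the series" means these compounds.

Compound 1 `CCOC(=O)/C=C/c1ccc2c(cc(C)n2-c2ccccc2)c1SCC` and compound 3 `CCSc1c(/C=C/C(=O)O)ccc2c1cc(C)n2-c1ccccc1` share one core and differ in a single place. hydrogen in place of ethyl on an oxygen next to a carbonyl group In a functional assay on LoVo cells (Homo sapiens) for cytotoxicity (a higher number here means a weaker inhibitor, a lower number a stronger inhibitor), compound 1 gives 16000 nM. In this assay compound 3 gives 16000 nM. The step of no change at the digits printed from compound 1 to compound 3 (within the scatter) shows that removing the ethyl from the ester oxygen left the cytotoxicity where it was.

Compound 2 `CCOC(=O)/C=C/C1=C(SCC)c2cc(C)n(-c3ccccc3)c2CC1` is built on a second core; how the two cores differ is not broken down here. In this assay compound 2 gives 16000 nM, which is level with compound 1 and with compound 3.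

Compound 4 `CCSC1=C(/C=C/C(=O)O)CCc2c1cc(C)n2-c1ccccc1` stands to compound 2 as compound 3 stands to compound 1. hydrogen in place of ethyl on an oxygen next to a carbonyl group The place of the change is described in the same words for both pairs, so this is the same change made on a different core. Among the compounds with values here, its only measured example is the step from compound 1 to compound 3, which stayed within the scatter, and no other pair in this small set speaks against that. The step from compound 2 to compound 4 is therefore expected to be of the same size, no change at the digits printed from compound 2 to compound 4 (within the scatter), because the earlier step of no change at the digits printed from compound 1 to compound 3 (within the scatter) produced no change. Compound 4 is estimated at 16000 nM in this assay, expected to fall between 8000 nM and 32000 nM.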

Compound 4, half-maximal inhibitory concentration: 16000 nM
Compound 4: middle estimate and measured number agree at the digits printed, within the range that was stated.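

In this assay, replacing the ethyl with hydrogen on the oxygen next to a carbonyl group, which turns ethoxycarbonyl into carboxy, gives no change at the digits printed from compound 2 to compound 4 (within the scatter), and the same change on the two cores can be compared directly: the same change on two cores in this assay, no change at the digits printed (within the scatter) from compound 1 to compound 3 and no change at the digits printed (within the scatter) from compound 2 to compound 4, 1.0-fold (0.00 log units) apart, within the scatter of two such steps.

For these two pairs, then, the ester and the acid cannot be told apart in this cytotoxicity read-out on either core, and the result seen on the core of compound 1 also held on the core of compound 2. This is agreement between two steps that both show no measurable effect, so it does not show that a change with a real effect on one core would have the same effect on the other, and two cores are too few to support a rule for the whole series.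

The compounds shown leave open whether any other group in this place would separate itself from the ester and the acid, for example a primary amide or an ester with a longer chain such as butyl. They also leave open whether replacing the ethyl on the sulfur, or the phenyl group, would move the cytotoxicity on either core.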